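Nucleoside series: ethynyl for thiophen-2-yl, cell growth read-out

A few compounds are considered here, and "the series" means these few. Any claim that something is new, unique, unknown or untested is made for them only; others in the source may bear on it.

Three compounds in this set have been run in a functional assay on HCT-116 cells (Homo sapiens), read by MTT assay, with a stated time of 72 h; a higher number here means a weaker inhibitor, a lower number a stronger inhibitor. Compound 1 `Cc1nc(N)c2c(-c3cccs3)cn([C@@H]3O[C@H](CO)[C@@H](O)[C@H]3O)c2n1` reaches only the limit of the assay, > 20000 nM. Compound 3 `C#Cc1cn([C@@H]2O[C@H](CO)[C@@H](O)[C@H]2O)c2nc(C)nc(N)c12` likewise gives only a limit, > 20000 nM. Compound 2 `COc1nc(N)nc2c1c(-c1cccs1)cn2[C@@H]1O[C@H](CO)[C@@H](O)[C@H]1O` also stops at a limit, > 20000 nM. The change from compound 1 to compound 3 is ethynyl in place of thiophen-2-yl on an aromatic carbon, and the step it makes, a step that the two limits leave unreadable from compound 1 to compound 3, cannot be read because of the limit of > 20000 nM in this assay, at which 3 of the 3 values shown sit. The difference between the core of compound 1 and the core of compound 2 is not broken down here.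

Compound 4 `C#Cc1cn([C@@H]2O[C@H](CO)[C@@H](O)[C@H]2O)c2nc(N)nc(OC)c12` is not yet measured. It differs from compound 2 by ethynyl in place of thiophen-2-yl on an aromatic carbon, the same change as from compound 1 to compound 3. The step from compound 2 to compound 4 in this assay is expected to be a step that the limit leaves unreadable from compound 2 to compound 4, which rests only on compound 1 at > 20000 nM and compound 3 at > 20000 nM both sitting at the limit. For compound 4 the estimate is 25000 nM, with a range from 10000 nM to 60000 nM, most probably again reported only as a limit.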

Compound 4, half-maximal inhibitory concentration: > 20000 nM
Compound 4 ended at the assay's limit (the forecaster's own chance of this, stated with the estimate: 85%); the middle value is on the limit's open side.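

In this assay compound 4 gives > 20000 nM, a limit and not a number. Compound 2 gives > 20000 nM, likewise a limit. No step can be read between compound 2 and compound 4: the limit of > 20000 nM in this assay, at which 4 of the 4 values shown sit.

The compounds shown leave open whether ethynyl in place of thiophen-2-yl changes the read-out at all, on either core.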